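The source may hold more compounds than are shown below. What is called first, only, known or untested is meant among the compounds shown, and "the series" means these compounds.

Measured compounds:
- Compound 1 `O=C(Nc1cccc(-n2cc(-c3ccncc3)c(-c3ccc(Cl)c(O)c3)n2)c1)Nc1cccc(C(F)(F)F)c1`: 23800 nM
- Compound 2 `COc1cc(-c2nn(-c3cccc(NC(=O)Nc4cc(C(F)(F)F)cc(C(F)(F)F)c4)c3)cc2-c2ccncc2)ccc1Cl`: 1570 nM
- Compound 3 `COc1cc(-c2nn(-c3cccc(NC(=O)c4cccc(C(F)(F)F)c4)c3)cc2-c2ccncc2)ccc1Cl`: 5170 nM

All three values come from a functional assay on COLO 205 cells (Homo sapiens) for inhibition, read by sulforhodamine B assay, with a stated time of 48 h; on this read-out lower numbers stand for stronger inhibition of growth and higher numbers for weaker inhibition of growth. Compound 1 has the highest number of the three, so it shows the weakest growth inhibition in the set. Compound 3 lies nearest to it and compound 2 furthest away, both beyond the usual scatter.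

Compound 4 `O=C(Nc1cccc(-n2cc(-c3ccncc3)c(-c3ccc(Cl)c(O)c3)n2)c1)Nc1ccc(Cl)c(Cl)c1` keeps the core of compound 1 but carries 3,4-dichlorophenyl in place of 3-(trifluoromethyl)phenyl on an amide-type nitrogen. Among the measured compounds shown here, no measured pair isolates this kind of change, so the data give no direct guide to its size. Since compound 1 stands at 23800 nM, the top of the measured values, a moderate shift toward a lower number in this assay is expected, though a step within the scatter remains possible. The expected change is a 2.0-fold lower number from compound 1 to compound 4 (0.30 log units; within the scatter). For compound 4 the estimated value is 12000 nM, with an expected range from 4000 nM to 35000 nM.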

Compound 4, concentration for total growth inhibition: 9490 nM
Compound 4: middle estimate off by 1.3-fold (0.10 log units), on the high side, and the stated range covers the measured number.
By their numbers in this assay, from the lowest: compound 2; then compounds 3 and 4 (each within the scatter of the next); then compound 1.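

Replacing 3-(trifluoromethyl)phenyl with 3,4-dichlorophenyl on the amide-type nitrogen gives a 2.5-fold lower number from compound 1 to compound 4 (0.40 log units; beyond the scatter) in this assay. Among the compounds shown here, this is the first change in the set made in a single place, and it shows that the aryl group at this position can alter the read-out on the shared core, although the step is modest. No measurement shown here accounts for the size or direction of this step.

Compounds 2 and 3 differ from the other compounds in more than one place, so the effects of their separate changes cannot be read. On these data alone, it remains open how this position would respond to a ring carrying a carboxylic acid or a dimethylamino group, and whether the same exchange would give a similar step with a methoxy group on the core.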